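A few compounds are considered here, and "the series" means these few. Any claim that something is new, unique, unknown or untested is made for them only; others in the source may bear on it.

The shared core carries, on an aromatic carbon of a six-membered aromatic ring of carbon only, a second aromatic ring whose small substituents vary. Compound 1 `Cc1ccccc1-c1cccc(COc2ccc([C@H](CC(=O)O)c3nccn3C)cc2)c1` bears a methyl on that ring, and in an assay on CHO cells for agonist activity at Free fatty acid receptor 1 (Homo sapiens), read by luminescence, with a stated time of 20 s, in the presence of a further agent that is not named here (a lower number here means that less compound is needed, a higher number that more compound is needed for the effect), compound 1 gives 43 nM. Compound 2 `Cn1ccnc1[C@@H](CC(=O)O)c1ccc(OCc2cccc(-c3ccccc3S(C)(=O)=O)c2)cc1` bears a methylsulfonyl in its place, and in this assay compound 2 gives 23000 nM. Compound 3 `Cc1cc(F)ccc1-c1cccc(COc2ccc([C@H](CC(=O)O)c3nccn3C)cc2)c1` keeps the methyl and adds a fluoro, and in this assay compound 3 gives 59 nM. Of the three numbers, compound 3 stands second highest, close to compound 1 but far from compound 2: a 1.4-fold higher number from compound 1 to compound 3 (0.14 log units; within the scatter), whereas a 390-fold lower number from compound 2 to compound 3 (2.59 log units; beyond the scatter).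

Compound 4 `Cc1cccc(C)c1-c1cccc(COc2ccc([C@H](CC(=O)O)c3nccn3C)cc2)c1` differs from compound 3 in one place: 2,6-dimethylphenyl in place of 4-fluoro-2-methylphenyl on an aromatic carbon. Going by the values given here, two measured steps bear on this. a 530-fold higher number from compound 1 to compound 2 (2.73 log units; beyond the scatter) shows that a bulky, polar substituent on this ring costs a great deal. a 1.4-fold higher number from compound 1 to compound 3 (0.14 log units; within the scatter) shows that a small change to the same ring, adding a fluoro, leaves the number essentially where it was. Trading the fluoro for a second methyl is again a small change, so for compound 4 a step of a 1.2-fold lower number from compound 3 to compound 4 (0.07 log units; within the scatter) is expected, with no direction beyond the scatter. Compound 4 is therefore estimated at 50 nM, within a range of 18 nM to 150 nM.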

Compound 4, half-maximal effective concentration: 58 nM
Compound 4: the middle estimate sits 1.2-fold (0.06 log units) below what was measured; the measured number falls inside the stated range.
By their numbers in this assay, from the lowest: compounds 1, 4 and 3 (each within the scatter of the next); then compound 2.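

In this assay, 2,6-dimethylphenyl in place of 4-fluoro-2-methylphenyl gives a 1.0-fold lower number from compound 3 to compound 4 (0.01 log units; within the scatter), and a second methyl on the ring of compound 1 gives a 1.3-fold higher number from compound 1 to compound 4 (0.13 log units; within the scatter), so this ring has now taken either a fluoro or a further methyl with no step beyond the scatter. Replacing 2-(methylsulfonyl)phenyl with 2,6-dimethylphenyl gives a 400-fold lower number from compound 2 to compound 4 (2.60 log units; beyond the scatter), which leaves compounds 1, 3 and 4 together and compound 2 alone far from them, now against a ring carrying two methyls as well as against rings carrying one. Nothing given here explains why methylsulfonyl stands so far from methyl on this ring.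

On these data alone, whether a methoxy, a chlorine, an amine or a carboxylic acid on this ring would stay with the methyl compounds or fall toward compound 2 remains open, as does the fate of a larger carbon group such as tert-butyl. All four compounds also share the same core, so how these steps would carry over to a different core is open too.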